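Exchanging the Benzyl Group of a Sulfonamide Series

The compounds below may be only part of what the source reports. "The series", "measured", "known", "first", "only" and "open" are said of these compounds alone.

In a functional assay on MCF7 cells (Homo sapiens) for inhibition, read by MTT assay, with a stated time of 72 h (on this read-out higher numbers stand for weaker inhibition of growth and lower numbers for stronger inhibition of growth), compound 1 `O=S(=O)(NCCCNCc1ccc(Cl)c(Cl)c1)c1cc(C(F)(F)F)cc(C(F)(F)F)c1` gives 2400 nM, the second highest of the three numbers measured. Compound 2 `O=S(=O)(NCCCNCc1ccc(Cl)c(C(F)(F)F)c1)c1cc(C(F)(F)F)cc(C(F)(F)F)c1` gives 3500 nM, and compound 3 `O=S(=O)(NCCCNCc1cccc2ccccc12)c1cc(C(F)(F)F)cc(C(F)(F)F)c1` gives 1400 nM. Starting from compound 1 the measured steps are a 1.5-fold higher number from compound 1 to compound 2 (0.16 log units; within the scatter) and a 1.7-fold lower number from compound 1 to compound 3 (0.23 log units; within the scatter); the only step beyond the scatter is a 2.5-fold lower number from compound 2 to compound 3 (0.40 log units; beyond the scatter). Compound 4 `COc1ccccc1CNCCCNS(=O)(=O)c1cc(C(F)(F)F)cc(C(F)(F)F)c1` differs from compound 1 by 2-methoxyphenyl in place of 3,4-dichlorophenyl on a saturated chain carbon bound to an amine nitrogen. Among the measured compounds shown here, no measured compound carries a 2-methoxyphenyl group, so the only guide is that exchanging the group on this chain carbon has so far moved the numbers little. The step from compound 1 to compound 4 is therefore expected to stay within the scatter, a 1.3-fold higher number from compound 1 to compound 4 (0.10 log units; within the scatter). Compound 4 is estimated at 3000 nM, with a range from 1200 nM to 7500 nM.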

Compound 4, concentration for 50% growth inhibition: 2600 nM
For compound 4 the middle estimate is 1.2-fold (0.06 log units) above the measured one; measured number inside the range.
By their numbers in this assay, from the lowest: compounds 3, 1, 4 and 2 (each within the scatter of the next, the first and the last beyond it).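

The exchange of 3,4-dichlorophenyl for 2-methoxyphenyl in this assay gives a 1.1-fold higher number from compound 1 to compound 4 (0.03 log units; within the scatter) even though both chlorine atoms leave and an oxygen with one hydrogen-bond acceptor enters. The steps of a 1.9-fold higher number from compound 3 to compound 4 (0.27 log units; within the scatter) and a 1.3-fold lower number from compound 2 to compound 4 (0.13 log units; within the scatter) also stay within the scatter, so this position accepts a group carrying oxygen instead of chlorine without a step beyond it. Nothing available explains this result.
The compounds shown leave open whether an amine or a carboxylic acid on the aromatic ring of this group would produce a larger step.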